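The source may hold more compounds than are shown below. What is called first, only, known or untested is meant among the compounds shown, and "the series" means these compounds.

Working notes on the series. Three members have been run in an ADME assay on microsomes from liver (Canis lupus familiaris) for metabolic stability, read by LC-MS, using NADPH, with a stated time of 10 min, tested at 0.1 uM; on this read-out higher numbers stand for fast clearance and lower numbers for slow clearance. Compound 1 `CC1SC(c2cccc(C(=O)NCCCCc3ccccc3)c2)N(c2ccc(C3CC3)cc2)C1=O` gives 1750 mL.min-1.g-1 in this assay. Compound 2 `O=C(NCCCCn1cccn1)c1cccc(C2SCC(=O)N2c2ccccn2)c1` gives 88.9 mL.min-1.g-1 in this assay. Compound 3 `C#Cc1cccc(N2C(=O)CSC2c2cccc(C(=O)NCCCCc3ccccc3)c2)c1` gives 973 mL.min-1.g-1 in this assay, the second highest of the three numbers: its gap to compound 1 lies within the scatter, whereas its gap to compound 2 lies beyond it.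

Compound 4 `Cc1cccc(N2C(=O)CSC2c2cccc(C(=O)NCCCCc3ccccc3)c2)c1` has not yet been measured in this assay. It differs from compound 3 in one place: methyl in place of ethynyl on an aromatic carbon. Among the compounds with values here, no pair of measured compounds shows this same difference, so the numbers themselves say nothing about how the clearance moves with it. The reference point is compound 3 at 973 mL.min-1.g-1 in this assay, with compound 1 at 1750 mL.min-1.g-1 as the nearest measured neighbour. On that basis the expected step of a 1.1-fold lower number from compound 3 to compound 4 (0.03 log units; within the scatter) is small and stays within the scatter, with no settled direction. Compound 4 is therefore estimated at 900 mL.min-1.g-1 in this assay, within a range from 400 mL.min-1.g-1 to 2000 mL.min-1.g-1.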

Compound 4, intrinsic clearance in microsomes: 749 mL.min-1.g-1
Beside the measured number, compound 4's estimate is 1.2-fold (0.08 log units) above it; measured number inside the range.
By their numbers in this assay, from the lowest: compound 2; then compounds 4, 3 and 1 (each within the scatter of the next, the first and the last beyond it).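

In this assay, within the data shown here, the change from 3-ethynylphenyl to 3-methylphenyl gives the first direct reading at this position, a 1.3-fold lower number from compound 3 to compound 4 (0.11 log units; within the scatter), and no earlier pair of compounds showed this difference. On this aromatic carbon, meta to a large group, ethynyl and methyl therefore cannot be told apart on clearance, despite the loss of the triple bond and one heavy atom. No measurement on hand explains this result.

The compounds shown leave open how clearance responds at this aromatic carbon to a nitrile, a methoxy group, an amine or a carboxylic acid, all of which would put atoms other than carbon there. Also open, as far as these compounds go, is whether methyl in place of ethynyl reads the same with a different amide chain.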